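Replacing pyrrolidin-1-yl with methoxy on the side chain

A few compounds are considered here, and "the series" means these few. Any claim that something is new, unique, unknown or untested is made for them only; others in the source may bear on it.

Measured in a functional assay on OVCAR-8 cells (Homo sapiens) for antiproliferative activity; on this read-out higher numbers stand for weaker inhibition and lower numbers for stronger inhibition:
compound 1 `CNC(=O)C[C@@H]1C[C@@H](c2ccc(Cl)c(Cl)c2)[C@H](NC(=O)c2cc(-c3c(Cl)cnn3C)c(Cl)o2)CN1` gives 1130 nM
compound 2 `Cn1ncc(Cl)c1-c1cc(C(=O)N[C@@H]2CN[C@H](CC(=O)O)C[C@H]2c2ccc(Cl)c(Cl)c2)oc1Cl` gives 5120 nM
compound 3 `Cn1ncc(Cl)c1-c1cc(C(=O)N[C@@H]2CN[C@H](CCN3CCCC3)C[C@H]2c2ccc(Cl)c(Cl)c2)oc1Cl` gives 1840 nM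

Compound 3 sits close to compound 1 and apart from compound 2. The numbers show a 1.6-fold higher number from compound 1 to compound 3 (0.21 log units; within the scatter), and also a 2.8-fold lower number from compound 2 to compound 3 (0.44 log units; beyond the scatter).

Compound 4 `COCC[C@@H]1C[C@@H](c2ccc(Cl)c(Cl)c2)[C@H](NC(=O)c2cc(-c3c(Cl)cnn3C)c(Cl)o2)CN1` keeps the shared core and alters only the side chain: methoxy in place of pyrrolidin-1-yl on a saturated chain carbon, two bonds along the chain from a saturated ring carbon. In words, this is methoxy in place of pyrrolidin-1-yl on a saturated chain carbon, two bonds along the chain from a saturated ring carbon.

Among the compounds with values here, no measured step makes this exact swap, so the guide is the other changes at this side chain. Compound 1 and compound 3 differ there without leaving the scatter. Within the data shown here, the only larger steps involve the carboxy group of compound 2, such as a 4.5-fold higher number from compound 1 to compound 2 (0.66 log units; beyond the scatter), and compound 4 has no such group. As far as these compounds go, a step beyond the scatter is therefore not expected, and the direction stays open. The estimated step is a 1.2-fold lower number from compound 3 to compound 4 (0.06 log units; within the scatter). For compound 4 the expected value is 1600 nM (estimated range 650 nM to 4000 nM).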

Compound 4, half-maximal inhibitory concentration: 1060 nM
Compound 4: middle estimate off by 1.5-fold (0.18 log units), on the high side; measured number inside the range.
By their numbers in this assay, from the lowest: compounds 4, 1 and 3 (each within the scatter of the next); then compound 2.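

In this assay, the pyrrolidin-1-yl ring gives way to methoxy, which has no ring and fewer heavy atoms, with a 1.7-fold lower number from compound 3 to compound 4 (0.24 log units; within the scatter) as the step, so among these compounds the ring is not required at this place. The methoxymethyl chain end also matches the methylcarbamoyl end, with a 1.1-fold lower number from compound 1 to compound 4 (0.03 log units; within the scatter) as the step, so three different chain ends now lie within the scatter of one another, while the carboxy compound stands apart, as a 4.8-fold lower number from compound 2 to compound 4 (0.68 log units; beyond the scatter) shows. No measurement here explains why the carboxy compound differs.

As far as these compounds go, it remains open whether a hydroxy group or a primary amine at the end of this chain would also fit with these three compounds. A longer chain carrying methoxy is equally untested by the compounds shown here.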